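Swapping a cyclohexylpropyl amide for a dichlorophenyl amide

The compounds below may be only part of what the source reports. "The series", "measured", "known", "first", "only" and "open" are said of these compounds alone.

Measured compounds:
- compound 1 `O=C(CCCC1CCCCC1)NCCCN1CCN(CCCNc2ccnc3cc(Cl)ccc23)CC1` — an ADME assay on L6 cells (Rattus norvegicus) for cytotoxicity; on this read-out higher numbers stand for weaker inhibition and lower numbers for stronger inhibition: "not determined" (no result reported)
- compound 2 `CC(=O)CCC(=O)NCCCN1CCN(CCCNc2ccnc3cc(Cl)ccc23)CC1` — this assay: 11000 nM

Compound 1 shares its core with compound 2; the two differ in the acyl part of the amide. For compound 1 the result in this assay is "not determined" (no result reported), so its position cannot be placed on the scale. Compound 2 is the only measured point, with 11000 nM in this assay.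

Compound 3 `O=C(NCCCN1CCN(CCCNc2ccnc3cc(Cl)ccc23)CC1)c1cc(Cl)cc(Cl)c1` is not yet measured. Its difference from compound 1 is 3,5-dichlorophenyl in place of 3-cyclohexylpropyl on a carbonyl carbon. Among the measured compounds shown here, no measured pair shows what this change does in this assay, so the size of the step can only be guessed. The expectation is a step of modest size, with compound 3 somewhat more toxic to the cells than the single measured point would suggest, though possibly within the scatter.

Compound 3 is estimated to give 5000 nM in this assay, with a range from 1500 nM to 20000 nM.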

Compound 3, half-maximal inhibitory concentration: 3000 nM
The estimate for compound 3 lay 1.7-fold (0.22 log units) above the measured number; the measured number falls inside the stated range.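

In this assay, among the compounds shown here, putting 3,5-dichlorophenyl in place of 2-acetylethyl on the carbonyl carbon gives a 3.7-fold lower number from compound 2 to compound 3 (0.56 log units; beyond the scatter) and so supplies the first readable step at this position, one that shows the group on this amide carbonyl can shift the number beyond the usual scatter, towards stronger inhibition of the cells. For the compounds shown here, the change from 3-cyclohexylpropyl to 3,5-dichlorophenyl itself cannot be read, as compound 1 has no number, so the size of that swap remains unknown and the only comparison rests on compound 2 and compound 3. Nothing available bears on why the number moves with this change.

The compounds shown leave open whether the step belongs to the aromatic ring or to its two chlorine atoms, since 3,5-dichlorophenyl differs from 2-acetylethyl in both at once and a plain phenyl or a 3-chlorophenyl on the same carbonyl carbon would separate the two. They also leave open how the number responds to a group of another kind in this place, such as a carboxylic acid, an amine or a longer carbon chain.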